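The source may report more compounds than this note shows. Statements on the series, on what has been measured and on what is new or still open speak of the compounds shown alone.

Compound 1 `NCc1cc(C(F)(F)F)ccc1CN(Cc1nc2ccccc2[nH]1)C1CCCc2cccnc21`: in a functional assay on CEM-CCRF cells for antagonist activity at C-X-C chemokine receptor type 4 (Homo sapiens), read by calcium flux (on this read-out lower numbers stand for stronger inhibition and higher numbers for weaker inhibition), compound 1 gives 51 nM
Compound 2 `COCc1ccc(CN(Cc2nc3ccccc3[nH]2)C2CCCc3cccnc32)c(CN)c1`: compound 2 gives 21 nM
Compound 3 `NCc1cc(C(N)=O)ccc1CN(Cc1nc2ccccc2[nH]1)C1CCCc2cccnc21`: compound 3 gives 15 nM

Among these three, compound 2 stands second highest. The step of a 1.4-fold lower number from compound 2 to compound 3 (0.15 log units; within the scatter) lies within the scatter, so compound 2 and compound 3 cannot be ordered; the step of a 2.4-fold lower number from compound 1 to compound 2 (0.39 log units; beyond the scatter) lies beyond it.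

Compound 4 `CO/N=C/c1ccc(CN(Cc2nc3ccccc3[nH]2)C2CCCc3cccnc32)c(CN)c1` differs from compound 2 by a group of 4 heavy atoms (2 carbon, 1 nitrogen, 1 oxygen; no ring) in place of a group of 3 heavy atoms (2 carbon, 1 oxygen; no ring), on an aromatic carbon. Going by the values given here, no measured step makes exactly this exchange. Among the compounds with values here, the steps that bear on it are a 2.4-fold lower number from compound 1 to compound 2 (0.39 log units; beyond the scatter) and a 3.4-fold lower number from compound 1 to compound 3 (0.53 log units; beyond the scatter), both modest, each replacing trifluoromethyl at this same aromatic carbon with a small group, and a 1.4-fold lower number from compound 2 to compound 3 (0.15 log units; within the scatter), where two such small groups swap without a step beyond the scatter. The entering group is of a similar size to those two, so compound 4 is expected to sit close to compound 2, with a step of a 1.2-fold higher number from compound 2 to compound 4 (0.08 log units; within the scatter) that is expected to stay within the scatter. Compound 4 is therefore estimated at 25 nM, with a range from 10 nM to 60 nM in this assay.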

Compound 4, half-maximal inhibitory concentration: 5 nM
Beside the measured number, compound 4's estimate is 5.0-fold (0.70 log units) above it, outside the stated range (below it).
By their numbers in this assay, from the lowest: compound 4; then compounds 3 and 2 (each within the scatter of the next); then compound 1.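

In this assay, going by these compounds alone, this aromatic carbon separates groups more sharply than the earlier compounds showed: methoxymethyl and carbamoyl could not be ordered, whereas the entering group of 4 heavy atoms gives a 4.2-fold lower number from compound 2 to compound 4 (0.62 log units; beyond the scatter) and a 3.0-fold lower number from compound 3 to compound 4 (0.48 log units; beyond the scatter), both beyond the scatter. Trifluoromethyl also has 4 heavy atoms, yet the exchange gives a 10-fold lower number from compound 1 to compound 4 (1.01 log units; beyond the scatter), the only large step at this position, so heavy-atom count alone does not set the number here. Nothing available accounts for this difference.

With a single group of this kind among the compounds shown, it remains open whether the double bond or the oxygen matters, and a nitrile or a carboxylic acid at this carbon would test this. On these data alone, all four compounds also keep the aminomethyl group, so whether the step would hold with a longer chain there remains unknown.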